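A Trifluoromethoxy Swap on a Weak Transport Protein Inhibitor

The source may hold more compounds than are shown below. What is called first, only, known or untested is meant among the compounds shown, and "the series" means these compounds.

Two compounds of this series share one core. Compound 1 `CCn1c(CNc2ccccc2)nnc1SCC(=O)Nc1ccc(C(=O)OC)cc1` carries in an assay on isolated protein for inhibition of long-chain fatty acid transport protein 1 (Mus musculus) (on this read-out higher numbers stand for weaker inhibition and lower numbers for stronger inhibition), only the entry "not determined" (no result reported), so it contributes no number. Compound 2 `CC/C(=N/OC)c1ccc2oc(CSc3nnc(CNc4ccccc4)n3CC)nc2c1` reaches just the limit of this assay, giving > 10000 nM. Compound 2 therefore stands at the limit of > 10000 nM in this assay, at which 1 of the 2 values shown sits, without a measured inhibition of the protein. Compound 3 `CCn1c(CNc2ccccc2)nnc1SCc1nc2cc(OC(F)(F)F)ccc2o1` differs from compound 2 in one place: a group of 5 heavy atoms (1 carbon, 1 oxygen, 3 fluorine; no ring) in place of a group of 6 heavy atoms (4 carbon, 1 nitrogen, 1 oxygen; no ring), on an aromatic carbon. Going by the values given here, no step between two measured compounds exists in this set, so the change has no precedent here. Because compound 2 sits at the limit of > 10000 nM in this assay, at which 1 of the 2 values shown sits, compound 3 is expected to remain weak, with a step of a number no higher from compound 2 to compound 3 (the limit leaves the size open) that stays within the usual scatter. The estimate for compound 3 in this assay is 10000 nM, with a range from 2000 nM to 50000 nM, and a limit rather than a number remains the more likely outcome.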

Compound 3, half-maximal inhibitory concentration: 91 nM
Compound 3: middle estimate off by 110-fold (2.04 log units), on the high side; measured number below the stated range.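

In this assay, the change gives an at least 100-fold lower number from compound 2 to compound 3 (2.04 log units; beyond the scatter), so what stands at this one place, on an aromatic carbon of the fused system of two rings, separates a compound without a measured inhibition from one with a clear number. The shared core alone therefore does not set the read-out; trifluoromethoxy is tolerated here where the unnamed group of 6 heavy atoms gives no number. The true size of the step remains unknown, as compound 2 has only a limit of the assay: the limit of > 10000 nM in this assay, at which 1 of the 3 values shown sits.

Going by these compounds, whether this result is particular to trifluoromethoxy stays open, and methoxy, a chlorine atom or a nitrile at the same place would test that. Also open, on these data alone, is whether a longer chain in place of the ethyl group on the shared core would keep the inhibition seen with compound 3.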